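Compound 2 to compound 3: a step without a precedent

A few compounds are considered here, and "the series" means these few. Any claim that something is new, unique, unknown or untested is made for them only; others in the source may bear on it.

Of the compounds shown here, two built on the shared core have been measured in a functional assay on HeLa cells (Homo sapiens) for cytotoxicity, read by MTT assay; a lower number here means a stronger inhibitor, a higher number a weaker inhibitor. Compound 1 `CC(=O)OCCC(=O)O[C@H](CC=C(C)C)C1=CC(=O)c2c(O)ccc(O)c2C1=O` gives 17300 nM in this assay. Compound 2 `CC(C)=CC[C@@H](OC(=O)C1CCCOC1)C1=CC(=O)c2c(O)ccc(O)c2C1=O` gives 60500 nM in this assay, the highest of the two numbers, with compound 1 as its nearest neighbour. Among the measured compounds shown here, the only measured step, a 3.5-fold higher number from compound 1 to compound 2 (0.54 log units; beyond the scatter), came with oxan-3-yl in place of 2-acetoxyethyl on a carbonyl carbon.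

Compound 3 `CCC(CO[C@H](CC=C(C)C)C1=CC(=O)c2c(O)ccc(O)c2C1=O)OC` has not yet been measured. It differs from compound 2 as follows: 2-methoxybutyl in place of (oxan-3-yl)carbonyl on an oxygen on a saturated carbon. For the measured compounds named here, this change removes the (oxan-3-yl)carbonyl altogether and places 2-methoxybutyl on the same oxygen, so it is not the kind of change traced by the one measured step, which only exchanged the group on the carbonyl carbon and shifted the number by a modest amount. Going by the values given here, with no step of the same kind to lean on, the expectation is a step of no more than roughly that size in either direction, centred a little toward the lower number seen for compound 1. Compound 3 is therefore expected to give 40000 nM in this assay, within 12000 nM to 130000 nM, corresponding to an expected step of a 1.5-fold lower number from compound 2 to compound 3 (0.18 log units; within the scatter).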

Compound 3, half-maximal inhibitory concentration: 63500 nM
Compound 3: the middle estimate sits 1.6-fold (0.20 log units) below what was measured, within the range that was stated.
By their numbers in this assay, from the lowest: compound 1; then compounds 2 and 3 (each within the scatter of the next).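

In this assay, 2-methoxybutyl in place of (oxan-3-yl)carbonyl gives a 1.0-fold higher number from compound 2 to compound 3 (0.02 log units; within the scatter), so on this oxygen the two groups cannot be told apart, even though the change removes the carbonyl and the six-membered ring together. Set against the group of compound 1, the same 2-methoxybutyl gives a 3.7-fold higher number from compound 1 to compound 3 (0.56 log units; beyond the scatter), which matches the direction of a 3.5-fold higher number from compound 1 to compound 2 (0.54 log units; beyond the scatter) and leaves compound 1, with its (2-acetoxyethyl)carbonyl, as the only one of the three set apart, with the lowest number. Nothing in the material shown explains why these groups read as they do.

The compounds shown leave open whether the lower number of compound 1 depends on its acetoxy group, a question that a 2-aminoethyl or a 2-carboxyethyl group on the same carbonyl carbon would address. They also leave open how a free hydroxyl on this saturated carbon, with neither a carbonyl group nor a 2-methoxybutyl on the oxygen, would compare with the three groups seen so far.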